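Two Chloro Substituents on a Quinoline Ether Pyridazinone

This account rests on a few compounds, and the source may have more. Where it says the series, first, only, none or still open, it means among the compounds named here.

Measured compounds:
compound 1, `COc1cc2c(Oc3ccc(NC(=O)c4nn(-c5ccccc5)c(=O)cc4C)cc3F)ccnc2cc1OCCCN1CCN(C)CC1`, 130 nM
compound 2, `COc1cc2c(Oc3ccc(NC(=O)c4nn(-c5ccc(Cl)cc5)c(=O)cc4C)cc3F)ccnc2cc1OCCCN1CCCCC1`, 230 nM
compound 3, `COc1cc2c(Oc3ccc(NC(=O)c4nn(-c5ccc(Cl)cc5)c(=O)cc4C)cc3F)ccnc2cc1OCCCN1CCN(C)CC1`, 40 nM

These three compounds were tested in a functional assay on MKN-45 cells (Homo sapiens) for inhibition, read by MTT assay, with a stated time of 72 h; on this read-out higher numbers stand for weaker inhibition and lower numbers for stronger inhibition. The difference between the cores of compound 1 and compound 2 is not broken down here. Compound 3 differs from compound 1 by chloro in place of hydrogen on an aromatic carbon, at a place para to a large group, and that change gave a 3.3-fold lower number from compound 1 to compound 3 (0.51 log units; beyond the scatter). Compound 3 also differs from compound 2 by the 4-methylpiperazin-1-yl in place of piperidin-1-yl on the chain, a step of a 5.8-fold lower number from compound 2 to compound 3 (0.76 log units; beyond the scatter). Compound 2 shows the highest number of the three, though its gap to compound 1 lies within the scatter.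

Compound 4, `COc1cc2c(Oc3ccc(NC(=O)c4nn(-c5ccc(Cl)cc5Cl)c(=O)cc4C)cc3F)ccnc2cc1OCCCN1CCCCC1`, is not yet measured. It differs from compound 2 by chloro in place of hydrogen on an aromatic carbon. This is the same kind of change as from compound 1 to compound 3, but here the chloro sits ortho to a large group and meta to a chloro group, rather than para to a large group, so the step may not carry over. Resting on the earlier step of a 3.3-fold lower number from compound 1 to compound 3 (0.51 log units; beyond the scatter), a smaller gain is expected, a 1.5-fold lower number from compound 2 to compound 4 (0.19 log units; within the scatter). For compound 4 the expected value is 150 nM, with a range from 60 nM to 400 nM.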

Compound 4, half-maximal inhibitory concentration: 80 nM
The estimate for compound 4 lay 1.9-fold (0.27 log units) above the measured number, within the range that was stated.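

In this assay, chloro in place of hydrogen on an aromatic carbon, which turns 4-chlorophenyl into 2,4-dichlorophenyl, gave a 2.9-fold lower number from compound 2 to compound 4 (0.46 log units; beyond the scatter). Set beside the earlier step, the change carried from one core to the other at much the same size: the same change on two cores in this assay, a 3.3-fold lower number (0.51 log units; beyond the scatter) from compound 1 to compound 3 and a 2.9-fold lower number (0.46 log units; beyond the scatter) from compound 2 to compound 4, 1.1-fold (0.05 log units) apart, within the scatter of two such steps. This does not show that the place of the chloro is of no account, since the two steps differ in core and in place at once, with the new chloro ortho to a large group and meta to a chloro group, and two steps are too few to make a rule for the series.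

The compounds shown leave open whether a fluoro or a methoxy group at the same place would give a like step. They also leave open what the 2,4-dichlorophenyl group would give when paired with the 4-methylpiperazin-1-yl chain of compound 3, or with a morpholin-4-yl group on that chain.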